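This account rests on a few compounds, and the source may have more. Where it says the series, first, only, none or still open, it means among the compounds named here.

Measured so far in a functional assay (aorta) with Oryctolagus cuniculus as the target; on this read-out higher numbers stand for weaker binding and lower numbers for tighter binding:

- Compound 1 (`COc1cc(C(C)=O)ccc1OCCCN1CCC(C(c2ccc(F)c(F)c2)c2ccc(F)c(F)c2)CC1`) gives 2.51 nM
- Compound 2 (`COc1cc(C(C)=O)ccc1OCCCN1CCC(C(c2ccc(F)cc2)C2CCCCC2)CC1`) gives 5.01 nM
- Compound 3 (`COc1cc(C(=O)O)ccc1OCCCN1CCC(C(c2ccc(F)cc2)c2ccc(F)cc2)CC1`) gives 79.4 nM

Compound 3 has the highest number of the three, so it binds the most weakly in this assay. Its gaps to both other compounds lie beyond the scatter. Compound 4 (`Fc1ccc(C(c2ccc(F)cc2)C2CCN(CCCOc3ccc(Br)cc3)CC2)cc1`) has not yet been measured. It differs from compound 3 by having 4-bromophenyl in place of 4-carboxy-2-methoxyphenyl on an oxygen on a saturated carbon. For the measured compounds named here, no measured pair isolates this change, so any forecast rests on indirect evidence. Of the three measured compounds, only compound 3 carries the 4-carboxy-2-methoxyphenyl group. Compound 1 at 2.51 nM and compound 2 at 5.01 nM lack it and show lower numbers, although they also differ from compound 3 elsewhere. The expected change is therefore towards a lower number and beyond the scatter, with an estimated step of a 6.6-fold lower number from compound 3 to compound 4 (0.82 log units; beyond the scatter). For compound 4 the estimate is 12 nM, with an expected range from 3 nM to 50 nM.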

Compound 4, dissociation constant: 1.59 nM
For compound 4 the middle estimate is 7.5-fold (0.88 log units) above the measured one; measured number outside the range, below it.
By their numbers in this assay, from the lowest: compounds 4, 1 and 2 (each within the scatter of the next, the first and the last beyond it); then compound 3.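

For the compounds shown here, at this position, on an oxygen on a saturated carbon, 4-bromophenyl in place of 4-carboxy-2-methoxyphenyl gives a 50-fold lower number from compound 3 to compound 4 (1.70 log units; beyond the scatter) in this assay, the only step here that isolates a single change. The position therefore has a large bearing on this read-out, and the entering group brings no hydrogen-bond donors or acceptors, so low numbers do not depend on the carboxy or methoxy groups: compound 4 has neither and gives 1.59 nM in this read-out. Nothing measured here explains the size of this step.

Going by these compounds, the change removes the carboxy and methoxy groups and adds the bromine all at once, so the share of each in the step remains open. On these data alone, it is also open whether 4-chlorophenyl, 4-methoxyphenyl or plain phenyl on the same oxygen would give a similarly low number.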